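This account rests on a few compounds, and the source may have more. Where it says the series, first, only, none or still open, it means among the compounds named here.

Measured compounds:
- compound 1, `Oc1ccc(-c2cc(-c3ccccc3)cc(-c3ccc(O)cc3)n2)cc1`: "not determined" (no result reported) in an assay on isolated protein for inhibition of DNA topoisomerase 1 (Homo sapiens), with a stated time of 30 min, tested at 20 uM; on this read-out lower numbers stand for a weaker effect and higher numbers for a stronger effect at the one concentration tested
- compound 2, `Oc1cccc(-c2cc(-c3ccccc3)nc(-c3ccccc3)c2)c1`: 0%

Going by the values given here, compound 1 carries no number, so compound 2 stands alone with the only value shown, and that value means no measurable effect at the tested concentration in this assay. Compound 3, `Oc1cccc(-c2cc(-c3ccccc3)nc(-c3ccncc3)c2)c1`, is the next compound in line and has not yet been tested. It differs from compound 2 in one place: pyridin-4-yl in place of phenyl on an aromatic carbon.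

Among the compounds with values here, no pair of measured compounds shows how a change of this kind moves the read-out, so the expected step rests on compound 2 alone. Starting from a compound with no effect, the expected step of a number 5 percentage points higher from compound 2 to compound 3 (within the scatter) is small and within the usual scatter, with little room to fall further. For compound 3 the estimated value in this assay is 5%, expected to lie between 0% and 20%.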

Compound 3, a percentage reported as inhibition, at one concentration (the size of the read-out at that concentration, not a potency): 0.9%
The estimate for compound 3 lay 4.1 percentage points above the measured number, and the stated range covers the measured number.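

In this assay, putting pyridin-4-yl in place of phenyl on the aromatic carbon next to the ring nitrogen gives a number 0.9 percentage points higher from compound 2 to compound 3 (within the scatter), so the two compounds cannot be told apart. Going by these compounds alone, this is the first sign of what this position tolerates: a ring nitrogen, counted as one hydrogen-bond acceptor that phenyl does not have, does not lift the read-out clear of the scatter at the one concentration tested. Nothing measured here offers an explanation for this result.

From the compounds shown here alone, whether a quite different group at this position, such as a primary amine, a carboxylic acid or a longer alkyl chain, would give a clear effect remains open. Also open, going by these compounds, is whether pyridin-4-yl would make any difference on a core carrying other substituents, or at a higher concentration.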